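Amide series with para substituent swaps: cyclopentyl at the benzylic ring

This account rests on a few compounds, and the source may have more. Where it says the series, first, only, none or still open, it means among the compounds named here.

Measured compounds so far:
- compound 1 `COc1cc(C2(C(=O)NCc3ccc(C(C)(C)C)cc3)CC2)ccc1NS(C)(=O)=O`: 750 nM
- compound 2 `CC(C(=O)NCc1ccc(Cl)cc1)c1ccc(NS(C)(=O)=O)c(F)c1`: 1060 nM
- compound 3 `CC(C)c1ccc(CNC(=O)C(C)c2ccc(NS(C)(=O)=O)c(F)c2)cc1`: 127 nM

In an assay on CHO cells for displacement of a labelled ligand from transient receptor potential cation channel subfamily V member 1 (Rattus norvegicus) (a higher number here means a weaker inhibitor, a lower number a stronger inhibitor), compound 2 gives 1060 nM, the highest number of the three. Compound 1 gives 750 nM, and the two values sit within the scatter of each other, so no order between them is claimed. Among the measured compounds shown here, compound 3 gives 127 nM, and the single clean step in the set, an 8.3-fold lower number from compound 2 to compound 3 (0.92 log units; beyond the scatter), is the only one that bears on the change considered here.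

Compound 4 `CC(C(=O)NCc1ccc(C2CCCC2)cc1)c1ccc(NS(C)(=O)=O)c(F)c1` is the same core as compound 2 with cyclopentyl in place of chloro on an aromatic carbon. Like the step to compound 3, this replaces chloro with a carbon-only group at the same place; cyclopentyl is larger than isopropyl, but there is no measured pair to say how that matters. The expectation therefore leans on compound 3: a drop in this assay of about the size of an 8.3-fold lower number from compound 2 to compound 3 (0.92 log units; beyond the scatter), with wide uncertainty.

Compound 4 is expected to give 150 nM, between 50 nM and 500 nM, which would mean an expected step of a 7.1-fold lower number from compound 2 to compound 4 (0.85 log units; beyond the scatter).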

Compound 4, inhibition constant: 93 nM
Compound 4: middle estimate off by 1.6-fold (0.21 log units), on the high side; measured number inside the range.
By their numbers in this assay, from the lowest: compounds 4 and 3 (each within the scatter of the next); then compounds 1 and 2 (each within the scatter of the next).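

In this assay the step to cyclopentyl, an 11-fold lower number from compound 2 to compound 4 (1.06 log units; beyond the scatter) on the shared core, shows that a second carbon-only group at this place, on an aromatic carbon para to a large group, also goes with a lower number than chloro, in the same direction as an 8.3-fold lower number from compound 2 to compound 3 (0.92 log units; beyond the scatter) in the isopropyl pair. Cyclopentyl and isopropyl cannot be told apart here, with a 1.4-fold lower number from compound 3 to compound 4 (0.14 log units; within the scatter), so adding the five-membered ring brings no readable change over isopropyl. No measurement at hand accounts for the difference from chloro.

Still open, on these data alone, is whether a larger carbon ring such as cyclohexyl, or a group carrying an amine or a carboxylic acid, would keep the number this low at this place. Compound 1 differs in more than one place, so its tert-butyl group cannot be compared with cyclopentyl.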